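Ester series at the orexin type 1 receptor: compound 3

This account rests on a few compounds, and the source may have more. Where it says the series, first, only, none or still open, it means among the compounds named here.

Among the compounds with values here, compound 2 `O=C(Oc1ccc2ccc(Cl)ccc1-2)c1cccs1` is one of two compounds measured in an assay on cells for displacement of a labelled ligand from Orexin/Hypocretin receptor type 1 (Homo sapiens), read by scintillation counting, with stated times of 10 min and 90 min, tested at 10 uM; a higher number here means more inhibition at the concentration tested (going by the name of the read-out), a lower number less inhibition. In this assay compound 2 gives 9.8%. Compound 1 `COC(=O)c1cccc2c(C(=O)c3ccccc3)cc(C(=O)c3ccc(C(Cl)(Cl)Cl)cc3)c-2c1` gives 10.4% in this assay, and the two numbers lie within the usual scatter of one another, so neither stands apart. Within the data shown here, no step between measured compounds is available for guidance. Compound 3 `COC(=O)CCC(=O)Oc1ccc2ccc(Cl)ccc1-2` differs from compound 2 by 2-(methoxycarbonyl)ethyl in place of thiophen-2-yl on a carbonyl carbon. With both measured numbers low and close together, no step beyond the scatter is expected in this assay, the change a number 1.8 percentage points lower from compound 2 to compound 3 (within the scatter) being estimated as small. Compound 3 is therefore expected to give about 8%, within 0% to 25%.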

Compound 3, a percentage reported as inhibition, at one concentration (the size of the read-out at that concentration, not a potency): 8%
Compound 3: the middle estimate sits on the measured number at the digits printed; measured number inside the range.
By their numbers in this assay, from the lowest: compounds 3, 2 and 1 (each within the scatter of the next).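

Putting 2-(methoxycarbonyl)ethyl in place of thiophen-2-yl on a carbonyl carbon gives a number 1.8 percentage points lower from compound 2 to compound 3 (within the scatter) in this assay at this low level of inhibition. Within the data shown here, this is the first step read at this position: an open chain with no ring and an aromatic five-membered ring read alike here, so this swap does not move the number clear of the scatter. Nothing at hand explains this. On these data alone, whether a carboxylic acid, an amine or a longer chain on this carbonyl carbon would move the number remains open, as does any change to the shared core.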